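The source may report more compounds than this note shows. Statements on the series, on what has been measured and on what is new or still open speak of the compounds shown alone.

Measured so far in an assay on isolated protein for inhibition of NEDD8-activating enzyme E1 regulatory subunit (Homo sapiens), read by Western blot, with stated times of 10 min and 30 min, tested at 25 uM; on this read-out higher numbers stand for more inhibition at the one concentration tested (going by the name of the read-out) and lower numbers for less inhibition:
compound 1 `CCCNC(=O)c1cccc2nc(OCC)n(Cc3ccc(-c4ccccc4-c4nnn[nH]4)cc3)c12`, giving 32.6%;
compound 2 `CCOc1nc2cccc(C(=O)Nc3ccncc3)c2n1Cc1ccc(-c2ccccc2-c2nnn[nH]2)cc1`, giving 39.8%.

Compound 1 holds the lowest of the two numbers, with compound 2 nearest: the step of a number 7.2 percentage points higher from compound 1 to compound 2 (within the scatter) lies within the scatter, so the two values cannot be ordered. For the measured compounds named here, the only measured step, from propyl to pyridin-4-yl on the amide-type nitrogen, therefore gives no change beyond the scatter.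

Compound 3 `CCOc1nc2cccc(C(=O)NCc3ccc(F)cc3)c2n1Cc1ccc(-c2ccccc2-c2nnn[nH]2)cc1` is not yet measured. It differs from compound 1 as follows: 4-fluorophenyl in place of ethyl on a saturated chain carbon bound to an amide-type nitrogen. The change sits on the same amide side chain that the measured step alters, and that step, a number 7.2 percentage points higher from compound 1 to compound 2 (within the scatter), was within the scatter. Going by the values given here, no step that places an aryl ring one carbon further out from the amide-type nitrogen has been measured, so the replacement of ethyl by 4-fluorophenyl on the saturated chain carbon rests on that single neighbouring step alone.

On this basis a step of a number 4.4 percentage points higher from compound 1 to compound 3 (within the scatter) is expected for compound 3, which is no change beyond the scatter. Compound 3 is thus estimated at 37%, within a range of 22% to 52%.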

Compound 3, a percentage reported as inhibition, at one concentration (the size of the read-out at that concentration, not a potency): 38.1%
Beside the measured number, compound 3's estimate is 1.1 percentage points below it; the measured number falls inside the stated range.
By their numbers in this assay, from the lowest: compounds 1, 3 and 2 (each within the scatter of the next).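

In this assay, 4-fluorophenyl in place of ethyl on the saturated chain carbon bound to the amide-type nitrogen gives a number 5.5 percentage points higher from compound 1 to compound 3 (within the scatter) and so brings in 7 heavy atoms and a six-membered aromatic ring where ethyl had 2 heavy atoms and no ring, without a change beyond the scatter. With 4-fluorobenzyl in place of pyridin-4-yl on the amide-type nitrogen, the series shows a number 1.7 percentage points lower from compound 2 to compound 3 (within the scatter) as a second step, so propyl, pyridin-4-yl and 4-fluorobenzyl on this nitrogen cannot be ordered from these three compounds. Nothing measured here offers an explanation for these results.

Still open, from the compounds shown here alone, is whether any group on the amide-type nitrogen moves the number beyond the scatter, for example a longer chain ending in a carboxylic acid or an amine. A plain benzyl group would also be needed to read the fluorine of compound 3 on its own, since the step from compound 1 changes the chain and adds the ring and fluorine together.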